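This account rests on a few compounds, and the source may have more. Where it says the series, first, only, none or still open, it means among the compounds named here.

In a functional assay on BXPC-3 cells (Homo sapiens) for inhibition, read by MTT assay, with a stated time of 7 days (a higher number here means a weaker inhibitor, a lower number a stronger inhibitor), compound 2 `CC(C)c1noc(N2CCN(C(=O)[C@@H]3CCCN(S(=O)(=O)c4ccc(S(=O)(=O)NC(C)(C)C)cc4)C3)CC2)n1` gives 2600 nM, the highest number of the three measured, though its gap to compound 1 is within the scatter. Compound 1 `CCN(CC)C(=O)c1ccc(S(=O)(=O)N2CCC[C@@H](C(=O)N3CCN(c4nc(C(C)C)no4)CC3)C2)cc1` gives 1400 nM, and the step of a 1.9-fold higher number from compound 1 to compound 2 (0.27 log units; within the scatter) stays within the scatter. Among the compounds with values here, compound 3 `CCOC(=O)C12CC(CN(S(=O)(=O)c3ccc(S(=O)(=O)N(CC)CC)cc3)C1)C2` gives 1200 nM; no single-point step joins it to compound 2, and its gap to compound 2 lies beyond the scatter. Compound 4 `CC(C)c1noc(N2CCN(C(=O)[C@@H]3CCCN(S(=O)(=O)c4ccc(S(=O)(=O)NC5CCC5)cc4)C3)CC2)n1` differs from compound 2 by cyclobutyl in place of tert-butyl on a sulfonamide nitrogen. Within the data shown here, no measured step changes this group; the only step touching this position, a 1.9-fold higher number from compound 1 to compound 2 (0.27 log units; within the scatter), exchanges the whole substituent and was within the scatter. This step is therefore expected to stay within the scatter, estimated as a 1.1-fold lower number from compound 2 to compound 4 (0.03 log units; within the scatter). For compound 4 the estimate in this assay is 2400 nM, in the range 1000 nM to 6000 nM.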

Compound 4, half-maximal inhibitory concentration: 3300 nM
Compound 4: middle estimate off by 1.4-fold (0.14 log units), on the low side; the measured number falls inside the stated range.
By their numbers in this assay, from the lowest: compounds 3, 1, 2 and 4 (each within the scatter of the next, the first and the last beyond it).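

In this assay, within the data shown here, the step of a 1.3-fold higher number from compound 2 to compound 4 (0.10 log units; within the scatter) is the first to change only the group on the sulfonamide nitrogen, and it shows that a cyclobutyl ring with the same carbon count as tert-butyl leaves the number within the scatter. The step of a 2.4-fold higher number from compound 1 to compound 4 (0.37 log units; beyond the scatter) exchanges the whole substituent and, unlike the exchange that gave compound 2, is modestly beyond the scatter. On these data alone, whether a methyl group, a hydroxyethyl chain or a carboxylic acid on this nitrogen would move the number remains open. Nothing at hand explains these numbers.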